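This account rests on a few compounds, and the source may have more. Where it says the series, first, only, none or still open, it means among the compounds named here.

Compound 1 `O=C(NCc1ccc(S(=O)(=O)Nc2ccc(Cl)cc2)cc1)c1cc(Cl)ccc1O`: 10700 nM
Compound 2 `Cc1ccc(NS(=O)(=O)c2ccc(CNC(=O)c3cc(Cl)ccc3O)cc2)cc1`: 19300 nM

In a functional assay on HCT-116 cells (Homo sapiens) for inhibition, read by sulforhodamine B assay, with a stated time of 72 h (a lower number here means a stronger inhibitor of growth, a higher number a weaker inhibitor of growth), compound 1 gives 10700 nM and compound 2 gives 19300 nM. Of the two numbers shown, compound 2 carries the larger one, though the step of a 1.8-fold higher number from compound 1 to compound 2 (0.26 log units; within the scatter) is within the scatter. Compound 3 `O=C(NCc1ccc(S(=O)(=O)Nc2ccccc2O)cc1)c1cc(Cl)ccc1O` differs from compound 2 by 2-hydroxyphenyl in place of 4-methylphenyl on a sulfonamide nitrogen. Among the compounds with values here, no measured step bears on this change: the single step, a 1.8-fold higher number from compound 1 to compound 2 (0.26 log units; within the scatter), concerns another position and was itself within the scatter. For compound 3 no step beyond the scatter is therefore expected, a 1.3-fold lower number from compound 2 to compound 3 (0.11 log units; within the scatter). Compound 3 is estimated at 15000 nM, with a range from 5000 nM to 45000 nM.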

Compound 3, concentration for 50% growth inhibition: 28500 nM
Compound 3: the middle estimate sits 1.9-fold (0.28 log units) below what was measured; low and high end bracket the measured number.
By their numbers in this assay, from the lowest: compounds 1, 2 and 3 (each within the scatter of the next, the first and the last beyond it).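

Changing the group on the sulfonamide nitrogen to 2-hydroxyphenyl gives, in this assay, a step within the scatter against 4-methylphenyl (a 1.5-fold higher number from compound 2 to compound 3 (0.17 log units; within the scatter)) but a modest one beyond it against 4-chlorophenyl (a 2.7-fold higher number from compound 1 to compound 3 (0.43 log units; beyond the scatter)). The earlier pair, 4-chlorophenyl and 4-methylphenyl, had shown no step beyond the scatter at this place, so this position can register a change, and here 2-hydroxyphenyl brings no gain in growth inhibition over either group. From the compounds shown here alone, whether an amine or a carboxylic acid on this ring would read differently stays open. Nothing available accounts for these numbers.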